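The source may hold more compounds than are shown below. What is called first, only, known or untested is meant among the compounds shown, and "the series" means these compounds.

Working notes on the series. Among the measured compounds shown here, in a functional assay on Caco-2 cells (Homo sapiens) for inhibition, read by sulforhodamine B assay, with a stated time of 48 h (on this read-out higher numbers stand for weaker inhibition and lower numbers for stronger inhibition), compound 3 `CCO[C@H]1C[C@@H](c2coc3ccc(C)cc3c2=O)N(c2ccccc2)O1` gives 31000 nM, the only true number among the values so far. Compound 1 `O=c1c([C@@H]2C[C@H](c3ccccc3)ON2c2ccccc2)coc2ccc(Br)cc12` gives > 60000 nM, which is a limit of the assay and not a number. Compound 2 `O=c1c([C@@H]2C[C@H](c3ccccc3)ON2c2ccccc2)coc2ccccc12` gives > 60000 nM, again a limit.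

Compound 4 `Cc1ccc2occ([C@@H]3C[C@H](c4ccccc4)ON3c3ccccc3)c(=O)c2c1` is the next to be read in this assay. The change from compound 3 is phenyl in place of ethoxy on a saturated ring carbon, next to the ring oxygen.

For the measured compounds named here, the only measured step, a step that the two limits leave unreadable from compound 1 to compound 2, has no readable size and concerns hydrogen in place of bromo on an aromatic carbon, so it gives no direct measure of this change. The more useful evidence is indirect: compound 1 and compound 2 both carry phenyl on that ring carbon, and both sit at the limit of > 60000 nM in this assay, at which 2 of the 3 values shown sit. A move toward weaker inhibition is therefore expected, with a fair chance that compound 4 also reads only as a limit. The expected change is a 2.3-fold higher number from compound 3 to compound 4 (0.35 log units; beyond the scatter).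

For compound 4 the estimated value is 70000 nM, with an expected range of 30000 nM to 150000 nM.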

Compound 4, half-maximal inhibitory concentration: 31700 nM
Estimate against measurement, compound 4: 2.2-fold (0.34 log units) above; low and high end bracket the measured number.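

In this assay, phenyl in place of ethoxy on a saturated ring carbon, next to the ring oxygen, is a 1.0-fold higher number from compound 3 to compound 4 (0.01 log units; within the scatter), so the two groups cannot be told apart at this position, even though phenyl brings a six-membered aromatic ring where ethoxy has none. Methyl in place of hydrogen on the aromatic carbon is an at least 1.8-fold lower number from compound 2 to compound 4 (0.27 log units; that floor lies within the scatter), and methyl in place of bromo there is an at least 1.8-fold lower number from compound 1 to compound 4 (0.27 log units; that floor lies within the scatter); both floors lie within the scatter, so neither step yet shows a real difference. Phenyl on the saturated ring carbon does not by itself tie a compound to the limit, as compound 4 carries it and reads as a true number, while compound 1 and compound 2 carry it and remain limits of the assay, not numbers: the limit of > 60000 nM in this assay, at which 2 of the 4 values shown sit.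

On these data alone, whether an amine or a carboxylic acid on the saturated ring carbon would read differently from ethoxy and phenyl stays open. Also open, as far as these compounds go, is how a longer chain or methoxy on the aromatic carbon would compare with methyl, and the true size of the methyl steps stays unknown while compound 1 and compound 2 read only as limits.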